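The source may report more compounds than this note shows. Statements on the series, on what has been measured and on what is new or still open speak of the compounds shown alone.

Measured so far in an ADME assay on the whole organism (strain C57BL/6J) for metabolic stability, with Mus musculus as the target (on this read-out higher numbers stand for a longer-lived compound and lower numbers for a shorter-lived compound), and nothing else
- Compound 1 (`O=C(O)c1cccc(C2CC2c2ccc(OCc3c(-c4c(Cl)cccc4Cl)noc3C3CC3)cc2Cl)c1`) gives 1 h
- Compound 2 (`O=C(O)c1ccc(C2CC2c2ccc(OCc3c(-c4c(Cl)cccc4Cl)noc3C3CC3)cc2Cl)cc1`) gives 0.5 h

Compound 2, at 0.5 h on this read-out, lies within the scatter of compound 1, so the two cannot be ranked. Compound 3 (`CC(C)n1nc(C(=O)O)cc1C1CC1c1ccc(OCc2c(-c3c(Cl)cccc3Cl)noc2C2CC2)cc1Cl`) differs from compound 2 as follows (3-carboxy-1-isopropyl-1H-pyrazol-5-yl in place of 4-carboxyphenyl on a saturated ring carbon), with 3-carboxy-1-isopropyl-1H-pyrazol-5-yl in place of 4-carboxyphenyl on a saturated ring carbon. Among the measured compounds shown here, the only measured step that bears on this is the exchange of 3-carboxyphenyl for 4-carboxyphenyl (a 2.0-fold lower number from compound 1 to compound 2 (0.30 log units; within the scatter)). For the measured compounds named here, that step stayed among carboxyphenyl groups, and no compound with a five-membered aromatic ring has yet been measured, so it is a weak guide. Going by the values given here, with that step as the only evidence, no change beyond the scatter is expected in this assay, in either direction. The expected step is small (a 1.4-fold higher number from compound 2 to compound 3 (0.15 log units; within the scatter)). The estimated half-life of compound 3 is 0.7 h (expected range 0.25 h to 2 h).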

Compound 3, half-life: 0.8 h
The estimate for compound 3 lay 1.1-fold (0.06 log units) below the measured number; the measured number falls inside the stated range.
By their numbers in this assay, from the lowest: compounds 2, 3 and 1 (each within the scatter of the next).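

In this assay, among the compounds shown here, the saturated ring carbon now carries a five-membered aromatic ring with 2 hetero atoms, where the earlier compounds held only carboxyphenyl groups. Putting 3-carboxy-1-isopropyl-1H-pyrazol-5-yl in place of 4-carboxyphenyl gives a 1.6-fold higher number from compound 2 to compound 3 (0.20 log units; within the scatter) and putting it in place of 3-carboxyphenyl gives a 1.3-fold lower number from compound 1 to compound 3 (0.10 log units; within the scatter) so the change of ring does not separate the three compounds on this read-out. Nothing in the data shown accounts for this result.

From the compounds shown here alone, whether the same ring without the isopropyl group, or with a longer chain in its place, would give a comparable half-life stays open. All three compounds carry a carboxylic acid, so the effect of an amide or a tetrazole at that point is also unknown.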